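Chain variation on the aryl ketone of compound 1

The source may hold more compounds than are shown below. What is called first, only, known or untested is meant among the compounds shown, and "the series" means these compounds.

Among the compounds with values here, compound 1 `CCCc1c(COc2ccc(C(=O)C(C)(C)Cc3nnn[nH]3)cc2)ccc(C(C)=O)c1O` gives 10.8 mg/kg in an in vivo functional assay on the whole organism (Rattus norvegicus) with cysteinyl leukotriene receptor (Homo sapiens) as the target (a higher number here means that more compound is needed for the effect, a lower number that less compound is needed), the highest of the three numbers measured so far. Compound 2 `CCCc1c(COc2ccc(C(=O)CCCC(=O)O)cc2)ccc(C(C)=O)c1O` gives 9.5 mg/kg; the step of a 1.1-fold lower number from compound 1 to compound 2 (0.06 log units; within the scatter) lies within the scatter. Within the data shown here, compound 3 `CCc1c(COc2ccc(C(=O)CC(C)(C)Cc3nnn[nH]3)cc2)ccc(C(C)=O)c1O` gives 1.1 mg/kg, a number well below that of compound 1, but compound 3 differs from compound 1 in two places, so no single step connects them. Compound 4 `CCCc1c(COc2ccc(C(=O)CCCCCCc3nnn[nH]3)cc2)ccc(C(C)=O)c1O` carries 6-(1H-tetrazol-5-yl)hexyl in place of 1-((1H-tetrazol-5-yl)methyl)-1-methylethyl on a carbonyl carbon. Among the measured compounds shown here, the only measured step that bears on this change, a 1.1-fold lower number from compound 1 to compound 2 (0.06 log units; within the scatter), shows that exchanging the chain on this carbonyl carbon left the dose essentially unchanged, so for compound 4 no step beyond the scatter in this assay is expected, a 1.4-fold lower number from compound 1 to compound 4 (0.13 log units; within the scatter) being the estimated change. Compound 4 is estimated at 8 mg/kg, with a range from 2.5 mg/kg to 20 mg/kg.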

Compound 4, dose for half-maximal effect: 8.5 mg/kg
Beside the measured number, compound 4's estimate is 1.1-fold (0.03 log units) below it; the measured number falls inside the stated range.
By their numbers in this assay, from the lowest: compound 3; then compounds 4, 2 and 1 (each within the scatter of the next).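

On this carbonyl carbon, 6-(1H-tetrazol-5-yl)hexyl in place of 1-((1H-tetrazol-5-yl)methyl)-1-methylethyl gives a 1.3-fold lower number from compound 1 to compound 4 (0.10 log units; within the scatter) in this assay, so a second tetrazole chain leaves the dose unchanged. On the saturated chain, 3-(1H-tetrazol-5-yl)propyl in place of carboxy gives a 1.1-fold lower number from compound 2 to compound 4 (0.05 log units; within the scatter), so this dose does not separate the tetrazole chain from the carboxy chain. No evidence is available on why these three compounds stay level.

Going by these compounds, whether the lower number of compound 3 belongs to its ethyl group or to its chain stays open. So does the effect of an amine or a sulfonamide at the chain end.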